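A Small Ester Change at a Quiet Corner

The source may report more compounds than this note shows. Statements on the series, on what has been measured and on what is new or still open speak of the compounds shown alone.

Of the compounds shown here, two in this set have been measured. Compound 1 `CC1=C(C(=O)OCC2CCC2)C(c2ccoc2)NC(=O)N1` and compound 2 `CC1=C(C(=O)OC2CCC2)C(c2cccs2)NC(=O)N1` share a core and an ester, and differ from each other in the ring hanging off the core. In an assay on membranes from HeLa cells for displacement of a labelled ligand from adenosine receptor A3 (Homo sapiens), read by scintillation counting, with a stated time of 180 min, tested at 1 uM (a lower number here means less inhibition, a higher number more inhibition at the concentration tested (going by the name of the read-out)), compound 1 gives 2%, and compound 2 gives 2%. Compound 2 therefore stands level with compound 1 at the digits shown, and the two values lie within the usual scatter of one another, so neither can be called the stronger.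

Compound 3 `CC1=C(C(=O)OCC2CCC2)C(c2cccs2)NC(=O)N1` has not been measured. It differs from compound 2 in one place: cyclobutylmethyl in place of cyclobutyl on an oxygen next to a carbonyl group. Compound 1 already carries the cyclobutylmethyl group on that oxygen, and its reading in this assay is 2%, so there is no sign in these data that the cyclobutylmethyl ester behaves differently from the cyclobutyl ester.

From compound 2 to compound 3 the step is expected to be essentially none beyond the scatter, a number 1 percentage points higher from compound 2 to compound 3 (within the scatter). For compound 3 in this assay the expected value is 3%, with a likely range from -8% to 15%.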

Compound 3, a percentage reported as inhibition, at one concentration (the size of the read-out at that concentration, not a potency): 1%
Beside the measured number, compound 3's estimate is 2 percentage points above it, and the stated range covers the measured number.
By their numbers in this assay, from the lowest: compounds 3, 1 and 2 (each within the scatter of the next).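

Compound 3 supplies what the first two compounds could not: a pair that differs only at the ester, and a pair that differs only in the ring on the shared core. In this assay, cyclobutylmethyl in place of cyclobutyl on an oxygen next to a carbonyl group gives a number 1 percentage points lower from compound 2 to compound 3 (within the scatter), so this change leaves no mark on the read-out at the concentration tested, at least with thiophen-2-yl in place. With the cyclobutylmethyl ester held fixed, thiophen-2-yl in place of furan-3-yl on a saturated ring carbon gives a number 1 percentage points lower from compound 1 to compound 3 (within the scatter), so that change also leaves no mark, and no measurement at hand offers any explanation for either result.

All three readings are small and come from a single concentration, so these compounds cannot show whether the ester position would matter in a compound with a clearly larger reading. Going by these compounds, whether an amine, a carboxylic acid, a benzyl group or a longer chain such as n-hexyl on that oxygen would shift the reading remains open.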